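The source may hold more compounds than are shown below. What is called first, only, known or untested is meant among the compounds shown, and "the series" means these compounds.

Three compounds have been measured so far in an ADME assay on MT4 cells (Homo sapiens) for cytotoxicity, read by MTT assay, with a stated time of 96 h (on this read-out higher numbers stand for lower toxicity in this test and lower numbers for higher toxicity in this test), and each value is a limit, not a number:

- Compound 1 `FC(F)(F)c1ccc(-c2nn(-c3ccccc3)cc2CNc2ccc(Cl)cc2)cc1` reads > 100000 nM as a limit
- Compound 2 `Cc1ccc(NCc2cn(-c3ccccc3)nc2-c2ccc(Cl)cc2)cc1` reads > 100000 nM as a limit
- Compound 3 `FC(F)(F)c1ccc(NCc2cn(-c3ccccc3)nc2-c2ccc(Cl)cc2)cc1` reads > 100000 nM as a limit

Compound 3 stands at > 100000 nM in this assay as a limit, so no number places it. What the series shows so far is the limit of > 100000 nM in this assay, at which 3 of the 3 values shown sit, and none of the three can be ranked against the others.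

Compound 4 `Clc1ccc(NCc2cn(-c3ccccc3)nc2-c2ccc(Cl)cc2)cc1` follows from compound 3 with chloro in place of trifluoromethyl on an aromatic carbon, at a place para to a large group. Among the compounds with values here, the one measured step at this place is a step that the two limits leave unreadable from compound 2 to compound 3 with trifluoromethyl in place of methyl on an aromatic carbon, and it gives no readable size. On the strength of that step, no change beyond the scatter is expected in this assay, and no direction can be given. The expected outcome is a number no higher from compound 3 to compound 4 (the limit leaves the size open) as an estimate, and the reading may well be a limit again. Compound 4 is estimated at 100000 nM in this assay, with 50000 nM to 100000 nM as the expected range.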

Compound 4, half-maximal cytotoxic concentration: > 100000 nM
Compound 4 ended at the assay's limit (the forecaster's own chance of this, stated with the estimate: 80%); the middle value sits exactly at the limit.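

In this assay compound 4 gives > 100000 nM, which is a limit and not a number. Its steps from compound 1, compound 2 and compound 3 cannot be read, since all four compounds sit at the same limit: the limit of > 100000 nM in this assay, at which 4 of the 4 values shown sit. The compounds shown leave open at what concentration any of them would reach half-maximal cytotoxicity in this assay, and so how the four rank against one another.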